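Swapping hydroxy for methyl at a cytotoxicity limit

The compounds below may be only part of what the source reports. "The series", "measured", "known", "first", "only" and "open" are said of these compounds alone.

Compound 1 `Oc1ccc(O)c(/C=N/Nc2ncccn2)c1`: 89400 nM
Compound 2 `O=C(N/N=C/c1ccccc1O)c1ncccn1`: > 150000 nM, a limit of the assay
Compound 3 `O=C(N/N=C/c1ccc(O)cc1O)c1ncccn1`: > 150000 nM, a limit of the assay

These results come from an ADME assay on cells (Peritoneal macrophage, Mus musculus, strain BALB/c) for cytotoxicity, with a stated time of 72 h; on this read-out lower numbers stand for higher toxicity in this test and higher numbers for lower toxicity in this test. Compound 3 gives only a limit there, > 150000 nM, and not a number. It shares that place with compound 2: the limit of > 150000 nM in this assay, at which 2 of the 3 values shown sit. Compound 4 `Cc1ccc(/C=N/NC(=O)c2ncccn2)c(O)c1` differs from compound 3 by methyl in place of hydroxy on an aromatic carbon. Going by the values given here, the one measured step that bears on this change is a step that the two limits leave unreadable from compound 2 to compound 3, with hydroxy in place of hydrogen on an aromatic carbon. Its size cannot be read, so it offers no size to carry over. Compound 1 gives 89400 nM, so a readable number does occur among these compounds. No step beyond the usual scatter is therefore expected in this assay, and compound 4 may well give a limit too. The expected change is a number no higher from compound 3 to compound 4 (the limit leaves the size open). For compound 4 the estimated value is 150000 nM, with an expected range from 70000 nM to 300000 nM.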

Compound 4, half-maximal cytotoxic concentration: > 150000 nM
Compound 4: only a limit was reported (the forecaster's own chance of this, stated with the estimate: 65%); the middle value lies on the limit itself.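

Compound 4 also gives only a limit and not a number, so no new step can be read between it and compound 2 or compound 3: the limit of > 150000 nM in this assay, at which 3 of the 4 values shown sit.

The compounds shown leave open how far compound 2, compound 3 and compound 4 truly differ in this assay.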